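Chain terminus change from compound 2 to compound 4

The source may hold more compounds than are shown below. What is called first, only, known or untested is meant among the compounds shown, and "the series" means these compounds.

Compound 1 `COC(=O)CCCc1onc(NS(=O)(=O)c2ccc(C(C)(C)C)cc2)c1Sc1cccc(OC)c1` gives 400 nM in an assay on A7R5 cells for displacement of a labelled ligand from Endothelin-1 receptor (Rattus norvegicus); a lower number here means a stronger inhibitor, a higher number a weaker inhibitor. Compound 2 `COc1cccc(Sc2c(NS(=O)(=O)c3ccc(C(C)(C)C)cc3)noc2CCO)c1` carries a hydroxy at the end of the same chain and gives 770 nM in this assay; this is the top of the measured numbers, but it is separated from compound 1 only by a 1.9-fold higher number from compound 1 to compound 2 (0.28 log units; within the scatter), a gap inside the scatter. Among the measured compounds shown here, compound 3 `CSc1c(NS(=O)(=O)c2ccc(C(C)(C)C)cc2)noc1C` returns a limit of this assay, > 100000 nM, not a number, and it is the one value sitting at the limit of > 100000 nM in this assay, at which 1 of the 3 values shown sits.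

Compound 4 `COc1cccc(Sc2c(NS(=O)(=O)c3ccc(C(C)(C)C)cc3)noc2CCCC(N)=O)c1` differs from compound 2 by carbamoylmethyl in place of hydroxy on a saturated chain carbon, two bonds along the chain from an aromatic carbon. For the measured compounds named here, the only measured step touching the same chain carbon is the one from compound 1 to compound 2, which swapped (methoxycarbonyl)methyl for hydroxy and moved the number by a 1.9-fold higher number from compound 1 to compound 2 (0.28 log units; within the scatter), within the scatter. The carbamoylmethyl of compound 4 restores a chain of the same length as in compound 1 with a different terminal group, so a step back toward the number of compound 1 is expected, and no step beyond the scatter is expected from compound 2 to compound 4 in this assay, a 1.5-fold lower number from compound 2 to compound 4 (0.19 log units; within the scatter). Compound 4 is therefore estimated at 500 nM, within 150 nM to 1600 nM.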

Compound 4, half-maximal inhibitory concentration: 6300 nM
The estimate for compound 4 lay 13-fold (1.10 log units) below the measured number; the measured number lies above the stated range.
By their numbers in this assay, from the lowest: compounds 1 and 2 (each within the scatter of the next); then compound 4. At a limit, above all of these: compound 3.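

Swapping hydroxy for carbamoylmethyl on this saturated chain carbon gives, in this assay, an 8.2-fold higher number from compound 2 to compound 4 (0.91 log units; beyond the scatter), so the end of the chain is not indifferent to what it carries, which the earlier step, a 1.9-fold higher number from compound 1 to compound 2 (0.28 log units; within the scatter), within the scatter, could not show. The methoxycarbonyl and carbamoyl ends sit on a chain of the same length, and amino in place of methoxy on the carbonyl carbon alone gives a 16-fold higher number from compound 1 to compound 4 (1.20 log units; beyond the scatter), so chain length by itself does not set the number, and the group on the carbonyl carbon does matter here. Among the compounds shown here, the one limit among the values shown has no bearing on this change, and nothing measured here accounts for the loss seen with the carbamoyl end.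

Open, going by these compounds, is how far the effect follows the amide itself, since only the methoxycarbonyl, hydroxy and carbamoyl ends can be compared on this chain. A carboxylic acid, a dimethylamide or an amine at the chain end, or a longer chain bearing the same carbamoyl group, would show whether the step belongs to the terminal group alone or to the group and its distance from the shared core together.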